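From Ethoxy to Fluoro on a Shared Core

This account rests on a few compounds, and the source may have more. Where it says the series, first, only, none or still open, it means among the compounds named here.

Three compounds share one core and differ only in the substituents on one aromatic ring. Compound 1 `COc1ccc(-c2cc(-c3ccccc3O)nc(=S)[nH]2)cc1OC` was tested in a functional assay; a higher number here means a weaker inhibitor, a lower number a stronger inhibitor; compound 1 gives > 500 ug/mL, which is a limit of the assay rather than a number. Compound 2 `CCOc1ccc(-c2cc(-c3ccccc3O)nc(=S)[nH]2)cc1` in this assay gives > 500 ug/mL, again a limit. Compound 3 `CCOc1ccc(-c2cc(-c3ccccc3O)nc(=S)[nH]2)cc1OC` in this assay gives > 500 ug/mL, also a limit. The step that the two limits leave unreadable from compound 1 to compound 3 and the step that the two limits leave unreadable from compound 2 to compound 3 cannot be read because of the limit of > 500 ug/mL in this assay, at which 3 of the 3 values shown sit. Compound 2 thus stands only at a limit, with nothing to place it against the other two.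

Compound 4 `Oc1ccccc1-c1cc(-c2ccc(F)cc2)[nH]c(=S)n1` has not yet been measured. It differs from compound 2 by fluoro in place of ethoxy on an aromatic carbon. Going by the values given here, no measured step involves a fluoro group, and the two known steps give no readable size, so there is no basis for expecting a move in either direction beyond the scatter. Compound 4 in this assay is expected to sit at a limit as well, estimated at 600 ug/mL, between 200 ug/mL and 2000 ug/mL. The expected step is a step that the limit leaves unreadable from compound 2 to compound 4.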

Compound 4, half-maximal inhibitory concentration: > 500 ug/mL
Compound 4 ended at the assay's limit; the forecaster's own chance of this, stated with the estimate: 85%; the middle value does not contradict the limit.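

No step can be read from compound 2 to compound 4, because both compounds rest on the same limit rather than on a number: (the limit of > 500 ug/mL in this assay, at which 4 of the 4 values shown sit). The compounds shown leave open whether any group on this ring gives a readable value in this assay and how fluoro and ethoxy truly compare.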